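A few compounds are considered here, and "the series" means these few. Any claim that something is new, unique, unknown or untested is made for them only; others in the source may bear on it.

Series notes, cytotoxicity arm. Compound 1 `CCOC(=O)c1cnc(N2CCN(Cc3ccc(C(=O)OC)cc3)CC2)nc1Oc1c(C)cc(-c2ccc(C#N)cc2)cc1C` carries a methoxycarbonyl on an aromatic carbon of its outer ring. In an ADME assay on MT4 cells (Homo sapiens) for cytotoxicity, read by MTT assay, with a stated time of 4 days (on this read-out higher numbers stand for lower toxicity in this test and lower numbers for higher toxicity in this test), compound 1 reaches only the assay limit, > 125000 nM. Compound 2 `CCOC(=O)c1cnc(N2CCN(Cc3ccc(Br)cc3)CC2)nc1Oc1c(C)cc(-c2ccc(C#N)cc2)cc1C` has bromo in that position instead. In this assay compound 2 likewise stops at the assay limit, > 125000 nM. The step that the two limits leave unreadable from compound 1 to compound 2 is accordingly of unknown size. Compound 2 therefore stands at the limit of > 125000 nM in this assay, at which 2 of the 2 values shown sit, and nothing finer is resolved for it. Compound 3 `CCOC(=O)c1cnc(N2CCN(Cc3ccc([N+](=O)[O-])cc3)CC2)nc1Oc1c(C)cc(-c2ccc(C#N)cc2)cc1C` follows by the change (nitro in place of bromo on an aromatic carbon), nitro in place of bromo on an aromatic carbon, para to a large group. Among the compounds with values here, the only measured step at this position was unreadable, so no direction can be drawn from it. In this assay the expectation is no step beyond the scatter, so that a number no higher from compound 2 to compound 3 (the limit leaves the size open) is expected to be nil. Compound 3 is estimated at 125000 nM, within 60000 nM to 300000 nM, and most likely again reported only as a limit.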

Compound 3, half-maximal cytotoxic concentration: > 125000 nM
Compound 3 gave a limit, no number; the forecaster's own chance of this, stated with the estimate: 75%; the middle value lies on the limit itself.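

The steps among compound 1, compound 2 and compound 3 cannot be read in this assay, as each value is only a limit: the limit of > 125000 nM in this assay, at which 3 of the 3 values shown sit.

The compounds shown leave open whether methoxycarbonyl, bromo and nitro differ at all on this read-out, since none gives a number.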